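Compound 2 to compound 4: a sulfonamide step

The compounds below may be only part of what the source reports. "The series", "measured", "known", "first", "only" and "open" are said of these compounds alone.

Of the compounds shown here, three have values so far in a functional assay on HT-29 cells (Homo sapiens) for antiproliferative activity, read by sulforhodamine B assay, with a stated time of 72 h (on this read-out higher numbers stand for weaker inhibition and lower numbers for stronger inhibition), and they share part of their structure. Compound 1 (`O=C1CS/C(=N/Nc2nncc3ccccc23)N1c1ccccc1`) gives 47 nM as its value. Compound 2 (`Cc1cc(C)nc(NS(=O)(=O)c2ccc(Nc3nncc4ccccc34)cc2)n1`) gives 3.3 nM as its value. Compound 3 (`C(=C/c1ccccc1)\C(=N\Nc1nncc2ccccc12)c1ccccc1`) gives 1.1 nM as its value. Compound 2 therefore holds the second highest number of the three, lower than compound 1 and higher than compound 3, and both gaps lie beyond the scatter.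

Compound 4 (`O=S(=O)(Nc1ncccn1)c1ccc(Nc2nncc3ccccc23)cc1`) has no value yet. Its change from compound 2 reads pyrimidin-2-yl in place of 4,6-dimethylpyrimidin-2-yl on a sulfonamide nitrogen and puts pyrimidin-2-yl in place of 4,6-dimethylpyrimidin-2-yl on a sulfonamide nitrogen. Within the data shown here, no measured pair shows this change, so there is no direct precedent for its size. Among the measured compounds shown here, the expectation rests on compound 2 at 3.3 nM as the only measured compound carrying the sulfonamide. The expected result is a 1.2-fold higher number from compound 2 to compound 4 (0.08 log units; within the scatter) in this assay and no step beyond the scatter is expected in either direction. For compound 4 the estimated value is 4 nM with an expected range from 1.3 nM to 13 nM as the working figure.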

Compound 4, half-maximal inhibitory concentration: 29 nM
Compound 4: middle estimate off by 7.3-fold (0.86 log units), on the low side, outside the stated range (above it).
By their numbers in this assay, from the lowest: compound 3; then compound 2; then compounds 4 and 1 (each within the scatter of the next).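

In this assay, among these compounds, replacing 4,6-dimethylpyrimidin-2-yl with pyrimidin-2-yl on a sulfonamide nitrogen gives an 8.8-fold higher number from compound 2 to compound 4 (0.94 log units; beyond the scatter), the first direct evidence that the substituent at this position affects the read-out and that the result is sensitive to a small change there. The two groups are alike in the counted features, each being one six-membered aromatic ring with the same numbers of hetero atoms, hydrogen-bond donors and hydrogen-bond acceptors and no net charge, so the computed difference lies in the carbon count and the methyl groups of the 4,6-dimethylpyrimidin-2-yl group. No measurement shown here accounts for the size of this step.

The present pair cannot tell whether a single methyl group, as in 4-methylpyrimidin-2-yl, would suffice to give the number seen with the 4,6-dimethylpyrimidin-2-yl group or whether both methyl groups are needed. It also leaves open how this sulfonamide nitrogen responds to other groups, such as 4,6-dimethoxypyrimidin-2-yl, 4,6-diethylpyrimidin-2-yl or a phenyl ring.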